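A few compounds are considered here, and "the series" means these few. Any claim that something is new, unique, unknown or untested is made for them only; others in the source may bear on it.

Measured so far in a functional assay on FaDu cells (Homo sapiens) for cytotoxicity, read by MTT assay, with a stated time of 72 h; on this read-out lower numbers stand for higher toxicity in this test and higher numbers for lower toxicity in this test:
Compound 1 `CCn1cc(C(=O)C(=O)Nc2ccc(OC)nc2)c2ccccc21` gives 219 nM
Compound 2 `COC(=O)CCn1cc(C(=O)C(=O)Nc2ccc(OC)nc2)c2ccccc21` gives 168 nM
Compound 3 `COc1ccc(NC(=O)C(=O)c2cn(C3CCCC3)c3ccccc23)cn1` gives 370 nM

Compound 3 sits close to compound 1, the gap being a 1.7-fold higher number from compound 1 to compound 3 (0.23 log units; within the scatter), and it is separated a little more clearly from compound 2, the gap being a 2.2-fold higher number from compound 2 to compound 3 (0.34 log units; beyond the scatter).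

The next compound is compound 4 `COc1ccc(NC(=O)C(=O)c2cn(CCC(=O)O)c3ccccc23)cn1`, which has 2-carboxyethyl in place of cyclopentyl on an aromatic nitrogen. Compound 2 carries 2-(methoxycarbonyl)ethyl on that same nitrogen, so the two steps above bear most directly on this change, together with a 1.3-fold lower number from compound 1 to compound 2 (0.12 log units; within the scatter). All three steps are small, and the largest is only modest. Among the compounds with values here, no measured compound carries 2-carboxyethyl, however, so they guide the likely size but cannot settle the direction. A small step is therefore expected in this assay, with more room towards higher numbers. On these data alone, the new group is untested. The expected change is a 1.4-fold higher number from compound 3 to compound 4 (0.13 log units; within the scatter). The estimate for compound 4 is 500 nM, with an expected range from 170 nM to 2000 nM.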

Compound 4, concentration lethal to 50% of the cells: > 10000 nM
Compound 4: a limit, no number; the forecaster's own chance of this, stated with the estimate: 10%; middle value at least 20-fold (1.30 log units) from the limit.
By their numbers in this assay, from the lowest: compounds 2, 1 and 3 (each within the scatter of the next, the first and the last beyond it). At a limit, above all of these: compound 4.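

In this assay, the result for compound 4 is a limit and not a number: the limit of > 10000 nM in this assay, at which 1 of the 4 values shown sits. Until now, changing the group on the aromatic nitrogen among ethyl, cyclopentyl and 2-(methoxycarbonyl)ethyl had produced only small steps, yet replacing just the methyl on the ester oxygen with hydrogen gives an at least 59-fold higher number from compound 2 to compound 4 (1.77 log units; beyond the scatter), and the other two comparisons are also large, at an at least 45-fold higher number from compound 1 to compound 4 (1.65 log units; beyond the scatter) and an at least 27-fold higher number from compound 3 to compound 4 (1.43 log units; beyond the scatter). This position is therefore not indifferent to what it carries, and the free carboxy group separates compound 4 from the rest, while its methyl ester in compound 2 stays with them.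

The compounds shown leave open whether this jump depends on the carboxylic acid alone or also on the length of the chain, which a longer chain ending in a carboxylic acid would test. A primary amide or an amine at the end of the same chain would show whether other end groups behave like the acid or like the ester.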